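The compounds below may be only part of what the source reports. "The series", "measured", "known", "first", "only" and "open" are said of these compounds alone.

Measured so far:
Compound 1 `Fc1ccc(-c2ccc3c(-c4cccnc4)cccc3c2)cc1` gives 2% in an assay for inhibition of steroid 17-alpha-hydroxylase/17,20 lyase (Homo sapiens), tested at 0.2 uM; a lower number here means a weaker effect, a higher number a stronger effect of the compound at the concentration tested.
Compound 2 `Fc1ccc(-c2ccc3cc(-c4cccnc4)ccc3c2)cc1` gives 0% in this assay.

Compound 2 and compound 1 lie within the scatter of each other, so neither can be called weaker or stronger; both show almost no inhibition. Compound 3 `Fc1ccc(-c2ccc3cc(Cn4ccnc4)ccc3c2)cc1` differs from compound 2 in one place: (1H-imidazol-1-yl)methyl in place of pyridin-3-yl on an aromatic carbon. Among the compounds with values here, no step between two measured compounds is available to guide this change, so the expectation rests only on the low readings of compound 2. The step of a number 10 percentage points higher from compound 2 to compound 3 (within the scatter) is expected to be small, upward at most and possibly not beyond the scatter. Compound 3 is estimated at 10%, within a range from 0% to 35%.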

Compound 3, a percentage reported as inhibition, at one concentration (the size of the read-out at that concentration, not a potency): 3%
For compound 3 the middle estimate is 7 percentage points above the measured one; measured number inside the range.
By their numbers in this assay, from the lowest: compounds 2, 1 and 3 (each within the scatter of the next).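

In this assay, putting (1H-imidazol-1-yl)methyl in place of pyridin-3-yl on this aromatic carbon gives a number 3 percentage points higher from compound 2 to compound 3 (within the scatter) and so cannot be told apart from no change. At this position, a five-membered aromatic ring with 2 hetero atoms leaves the reading as close to nothing as the six-membered ring did. Nothing available offers an explanation for this reading. As far as these compounds go, whether any group on this carbon can produce clear inhibition at the tested concentration stays open. An amine, a carboxylic acid or a longer chain ending in imidazole could help answer that.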